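A few compounds are considered here, and "the series" means these few. Any claim that something is new, unique, unknown or untested is made for them only; others in the source may bear on it.

In a functional assay on DLD-1 cells (Homo sapiens) for cytotoxicity, with a stated time of 48 h (on this read-out lower numbers stand for stronger inhibition and higher numbers for weaker inhibition), compound 1 (`Cc1ccc2c(=O)cc(/C=C/[S+](C)[O-])oc2c1`) gives 7000 nM. Compound 2 (`CC(=O)Oc1ccc2oc(/C=C/[S+](C)[O-])cc(=O)c2c1`) is the starting point of this account, yet it offers no number to start from. For compound 2 the assay reports only a limit, > 10000 nM.

Compound 3 (`CC(C)COc1ccc2oc(/C=C/[S+](C)[O-])cc(=O)c2c1`) differs from compound 2 in one place, with isobutyl in place of acetyl on an oxygen on an aromatic ring, which is an acetoxy to isobutoxy change (isobutyl in place of acetyl on an oxygen on an aromatic ring). It has not yet been measured in this assay.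

Among the measured compounds shown here, no measured pair of compounds shows what this change does, so the expectation has little to rest on. For the measured compounds named here, the one firm reading is that of compound 1 at 7000 nM, which shows that a compound of this kind can give a number in this assay. A modest change towards stronger inhibition is expected, estimated as an at least 1.2-fold lower number from compound 2 to compound 3 (0.09 log units; that floor lies within the scatter), and it may not exceed the usual scatter. Another result that gives only a limit would be no surprise. Compound 3 is estimated at 8000 nM, with an expected range of 3000 nM to 20000 nM.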

Compound 3, half-maximal inhibitory concentration: 5000 nM
The estimate for compound 3 lay 1.6-fold (0.20 log units) above the measured number; low and high end bracket the measured number.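

Among the compounds shown here, with compound 3, isobutyl on an oxygen on an aromatic ring gives a number in this assay, whereas acetyl at this place gives only a limit, so the acetoxy to isobutoxy change can now be read for the first time. The change reads as an at least 2.0-fold lower number from compound 2 to compound 3 (0.30 log units; that floor lies within the scatter). This figure is a floor and not a measured size, so the true step may be larger, and the reading for compound 2 remains a limit: the limit of > 10000 nM in this assay, at which 1 of the 3 values shown sits.

The compounds shown leave open whether a smaller ether such as methoxy, a longer chain such as n-hexyl, or a benzyl group on the same oxygen would give a lower or a higher number in this assay than compound 3 does. They also leave open how much of the step belongs to the chain and how much to the loss of the acetyl carbonyl, a question that a pair holding a longer acyl group such as isovaleryl against isobutyl could begin to answer.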